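Amide Ring Swap in a Cathepsin S Nitrile Series

The compounds below may be only part of what the source reports. "The series", "measured", "known", "first", "only" and "open" are said of these compounds alone.

Compound 1: `N#CC1(NC(=O)[C@@H]2C[C@@H](S(=O)(=O)c3ccccc3)C[C@H]2C(=O)N2CC3(COC3)C2)CC1`, 3 nM
Compound 2: `N#CC1(NC(=O)[C@@H]2C[C@@H](S(=O)(=O)c3ccccc3)C[C@H]2C(=O)N2CCNCC2)CC1`, 11 nM

In an assay on isolated protein for inhibition of cathepsin S (Homo sapiens), read by fluorescence, with a stated time of 20 min (a higher number here means a weaker inhibitor, a lower number a stronger inhibitor), compound 2 gives 11 nM, the higher of the two numbers; compound 1 gives 3 nM. Compound 3 is `N#CC1(NC(=O)[C@@H]2C[C@@H](S(=O)(=O)c3ccccc3)C[C@H]2C(=O)N2CCCC2)CC1`, differing from compound 2 by pyrrolidin-1-yl in place of piperazin-1-yl on a carbonyl carbon. Among the compounds with values here, the only measured step at this carbonyl carbon is a 3.7-fold higher number from compound 1 to compound 2 (0.56 log units; beyond the scatter), a modest change on exchanging one amide ring for another. A comparable modest step is therefore expected here, downward, since the piperazin-1-yl compound 2 holds the weaker number. Compound 3 is estimated at 5 nM (range 2 nM to 15 nM), an expected step of a 2.2-fold lower number from compound 2 to compound 3 (0.34 log units; beyond the scatter).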

Compound 3, half-maximal inhibitory concentration: 2 nM
Compound 3: middle estimate off by 2.5-fold (0.40 log units), on the high side, and the stated range covers the measured number.
By their numbers in this assay, from the lowest: compounds 3 and 1 (each within the scatter of the next); then compound 2.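

In this assay, the step of a 5.5-fold lower number from compound 2 to compound 3 (0.74 log units; beyond the scatter) shows that the amide ring on this carbonyl carbon needs no hydrogen-bond donor or acceptor to give a low number, and that compound 2 is the one that stands apart. The step of a 1.5-fold lower number from compound 1 to compound 3 (0.18 log units; within the scatter) places two quite different rings level with each other at this position. Nothing available explains these differences. The compounds leave open how a piperidin-1-yl ring, or a dimethylamino group with no ring at all, would read on this carbonyl carbon.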